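Dimethylamino in Place of Methyl on the Butenamide Chain

This account rests on a few compounds, and the source may have more. Where it says the series, first, only, none or still open, it means among the compounds named here.

Compound 2 `CC/C=C/C(=O)Nc1cc2c(N3CCc4ccccc43)ncnc2cc1O[C@@H]1CCOC1` gives 9590 nM in a functional assay on PC-3 cells (Homo sapiens) for antiproliferative activity, read by MTT assay, with a stated time of 72 h (a higher number here means a weaker inhibitor, a lower number a stronger inhibitor), the higher of the two numbers measured, while compound 1 `CC(C)=CC(=O)Nc1cc2c(N3CCc4ccccc43)ncnc2cc1O[C@@H]1CCOC1` gives 4620 nM, with a 2.1-fold higher number from compound 1 to compound 2 (0.32 log units; beyond the scatter). Compound 3 `CN(C)C/C=C/C(=O)Nc1cc2c(N3CCc4ccccc43)ncnc2cc1O[C@@H]1CCOC1` differs from compound 2 by dimethylamino in place of methyl on a saturated chain carbon bound to a double-bonded chain carbon. For the measured compounds named here, no measured step touches a dimethylamino group; the single step from compound 1 to compound 2 changes a different part of the chain and offers no direct guide. Compound 3 is therefore expected to land near compound 2, with a step of a 1.9-fold lower number from compound 2 to compound 3 (0.28 log units; within the scatter) that may well fall within the scatter. The estimate for compound 3 in this assay is 5000 nM, within 1500 nM to 18000 nM.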

Compound 3, half-maximal inhibitory concentration: 1230 nM
For compound 3 the middle estimate is 4.1-fold (0.61 log units) above the measured one; measured number outside the range, below it.
By their numbers in this assay, from the lowest: compound 3; then compound 1; then compound 2.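

In this assay, dimethylamino in place of methyl on a saturated chain carbon bound to a double-bonded chain carbon gives a 7.8-fold lower number from compound 2 to compound 3 (0.89 log units; beyond the scatter), showing that this position can move the number well beyond the scatter. Against the other chain, the change gives a 3.8-fold lower number from compound 1 to compound 3 (0.57 log units; beyond the scatter), which makes compound 3 the strongest inhibitor of the three. Nothing available explains why this change lowers the number. From the compounds shown here alone, it remains open whether another amine at this place, such as pyrrolidin-1-yl or morpholin-4-yl, would do the same. Going by these compounds, the effect of a longer chain between the amine and the double bond also remains open.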